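A few compounds are considered here, and "the series" means these few. Any claim that something is new, unique, unknown or untested is made for them only; others in the source may bear on it.

Compound 2 `c1coc(-c2cc(-c3cccs3)nc(-c3cccs3)c2)c1` stands level with compound 1 `c1ccc(-c2cc(-c3cccs3)nc(-c3cccs3)c2)nc1` on the numbers at hand: in a functional assay on A549 cells (Homo sapiens) for antiproliferative activity (a higher number here means that more compound is needed for the effect, a lower number that less compound is needed), compound 2 gives 118000 nM, and compound 1 gives 118000 nM. Compound 3 `c1csc(-c2cc(-c3cccs3)nc(-c3cccs3)c2)c1` differs from compound 2 by thiophen-2-yl in place of furan-2-yl on an aromatic carbon. For the measured compounds named here, the one measured step that bears on this change is no change at the digits printed from compound 1 to compound 2 (within the scatter), and it lay within the scatter. On that basis no step beyond the scatter is expected here either, no change at the digits printed from compound 2 to compound 3 (within the scatter). Compound 3 is therefore estimated at 118000 nM, with a range from 50000 nM to 250000 nM.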

Compound 3, half-maximal effective concentration: 118000 nM
The estimate for compound 3 equals the measured number at the digits printed; the measured number falls inside the stated range.
By their numbers in this assay, from the lowest: compounds 1, 2 and 3 (each within the scatter of the next).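

In this assay, thiophen-2-yl in place of furan-2-yl gives no change at the digits printed from compound 2 to compound 3 (within the scatter) and thiophen-2-yl in place of pyridin-2-yl gives no change at the digits printed from compound 1 to compound 3 (within the scatter) at this position, opposite the ring nitrogen. Pyridin-2-yl, furan-2-yl and thiophen-2-yl now all read alike here, where the earlier compounds had compared only the first two. Nothing available explains this flat reading. Still open, as far as these compounds go, is whether a group of another kind at this position, such as an amine, a carboxylic acid or a longer chain, would shift the number.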